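The compounds below may be only part of what the source reports. "The series", "measured", "known", "first", "only" and "open" are said of these compounds alone.

In an assay for inhibition of protein disulfide-isomerase (Homo sapiens), with a stated time of 1 h (a lower number here means a stronger inhibitor, a higher number a weaker inhibitor), compound 1 `Cc1ccnc(NC(c2ccc(F)cc2)c2ccc3cccnc3c2O)c1` gives 140 nM, the second highest of three numbers; compound 3 `Oc1c(C(Nc2ccccc2)c2ccccc2)ccc2cccnc12` gives 110 nM, within the scatter of compound 1, while compound 2 `Oc1c(C(c2ccc(F)cc2)N2CCCCC2)ccc2cccnc12` gives 690 nM, the furthest. Within the data shown here, the only step between compounds differing in a single place, a 4.9-fold higher number from compound 1 to compound 2 (0.69 log units; beyond the scatter), alters the group on the saturated chain carbon and so does not bear on the change to compound 4 `Cc1ccnc(NC(c2ccc([N+](=O)[O-])cc2)c2ccc3cccnc3c2O)c1`: nitro in place of fluoro on an aromatic carbon. Compound 3 carries no group on its six-membered aromatic ring of carbon only and differs from compound 1 in more than one place, yet sits within its scatter. Among the measured compounds shown here, with no step speaking directly to a nitro in place of fluoro, the expectation is a step of a 1.1-fold higher number from compound 1 to compound 4 (0.03 log units; within the scatter), nothing beyond the scatter. Compound 4 is estimated at 150 nM, range 50 nM to 450 nM.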

Compound 4, half-maximal inhibitory concentration: 530 nM
Beside the measured number, compound 4's estimate is 3.5-fold (0.55 log units) below it; measured number outside the range, above it.
By their numbers in this assay, from the lowest: compounds 3 and 1 (each within the scatter of the next); then compounds 4 and 2 (each within the scatter of the next).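

In this assay, the change from 4-fluorophenyl to 4-nitrophenyl is not silent: a 3.8-fold higher number from compound 1 to compound 4 (0.58 log units; beyond the scatter). The group on this aromatic carbon, para to a large group, therefore affects the read-out, which the earlier step, made on the saturated chain carbon, could not show. Nothing available accounts for this shift.

With one step at this place, no trend across groups can be drawn. From the compounds shown here alone, how an amine, a methoxy group or a nitrile would read here remains open, as does whether the step carries over to other groups on the saturated chain carbon.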